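The compounds below may be only part of what the source reports. "The series", "measured", "known", "first", "only" and "open" are said of these compounds alone.

In a functional assay on BaF3 cells (Mus musculus) for antiproliferative activity, read by CCK-8 assay and cell counting, with a stated time of 76 h (on this read-out lower numbers stand for stronger inhibition and higher numbers for weaker inhibition), the measured compounds have so far returned only limits. Compound 1 `COc1cc2nccc(Oc3ccc(Nc4nn(C)cc4C(=O)NCc4ccccc4)cc3)c2cc1C(N)=O` gives > 10000 nM, a limit of the assay. Compound 2 `COc1cc2nccc(Oc3ccc(Nc4nn(C)cc4C(=O)NCC4CCCO4)cc3)c2cc1C(N)=O` gives > 10000 nM, also a limit. Compound 3 `COc1cc2nccc(Oc3ccc(Nc4nn(C)cc4C(=O)NCC(C)C)cc3)c2cc1C(N)=O` gives > 10000 nM, again a limit. Compound 2 therefore has no numerical position in the series: the limit of > 10000 nM in this assay, at which 3 of the 3 values shown sit.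

Compound 4 `COc1cc2nccc(Oc3ccc(Nc4nn(C)cc4C(=O)Nc4ccccc4F)cc3)c2cc1C(N)=O` differs from compound 2 by 2-fluorophenyl in place of (oxolan-2-yl)methyl on an amide-type nitrogen. The nearest evidence is a step that the two limits leave unreadable from compound 1 to compound 2 and a step that the two limits leave unreadable from compound 2 to compound 3, with a step that the two limits leave unreadable from compound 1 to compound 3 alongside. None gives a size, and none puts an aromatic ring directly on that nitrogen. No step beyond the scatter is therefore expected in this assay, and no direction can be assigned. The expected step is a number no higher from compound 2 to compound 4 (the limit leaves the size open). Compound 4 is estimated at 10000 nM, with an expected range of 2500 nM to 30000 nM.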

Compound 4, half-maximal inhibitory concentration: 1710 nM
Compound 4: the middle estimate sits 5.8-fold (0.77 log units) above what was measured; measured number outside the range, below it.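

In this assay, among these compounds, a ring placed directly on the amide-type nitrogen gives the first readable number, and 2-fluorophenyl improves on (oxolan-2-yl)methyl (an at least 5.8-fold lower number from compound 2 to compound 4 (0.76 log units; beyond the scatter)), isobutyl (an at least 5.8-fold lower number from compound 3 to compound 4 (0.76 log units; beyond the scatter)) and benzyl (an at least 5.8-fold lower number from compound 1 to compound 4 (0.76 log units; beyond the scatter)). The steps among compound 1, compound 2 and compound 3 cannot be read, and all three remain at a limit: the limit of > 10000 nM in this assay, at which 3 of the 4 values shown sit.

With compound 4 alone, the contribution of the aromatic ring cannot be separated from that of the fluorine. A plain phenyl or a pyridyl on that nitrogen would address this.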